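From Thiophene to Pyrazole: Expecting a Weaker Agonist

The source may hold more compounds than are shown below. What is called first, only, known or untested is meant among the compounds shown, and "the series" means these compounds.

Of the compounds shown here, three sharing one core have been tested in a functional assay for activation of Alpha-1A adrenergic receptor (Homo sapiens), read by calcium flux; a lower number here means that less compound is needed, a higher number that more compound is needed for the effect. Compound 1, `c1ccc(-c2ccncn2)c(OCC2=NCCN2)c1`, carries a pyrimidin-4-yl group on the aromatic carbon, and in this assay compound 1 gives < 100000 nM, which is a limit of the assay and not a number. Compound 2, `c1coc(-c2ccccc2OCC2=NCCN2)c1`, carries furan-2-yl in that place and gives 1.26 nM in this assay. Compound 3, `c1ccc(-c2ccsc2)c(OCC2=NCCN2)c1`, carries thiophen-3-yl and gives 0.251 nM in this assay, the lowest of the two numbers shown. For the measured compounds named here, the only readable step is a 5.0-fold lower number from compound 2 to compound 3 (0.70 log units; beyond the scatter); both steps starting from compound 1 stay unreadable because of the limit of < 100000 nM in this assay, at which 1 of the 3 values shown sits.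

Compound 4, `c1ccc(-c2cc[nH]n2)c(OCC2=NCCN2)c1`, has not yet been measured. Its change from compound 3 is 1H-pyrazol-3-yl in place of thiophen-3-yl on an aromatic carbon. Going by the values given here, no measured step covers exactly this swap. The ring that enters holds two nitrogens, as does the ring of compound 1, whose value sits at the limit; the ring that leaves gave the lowest number shown. On that basis the expected step is an 80-fold higher number from compound 3 to compound 4 (1.90 log units; beyond the scatter), towards a higher number in this assay, with wide uncertainty. For compound 4 the estimate in this assay is 20 nM, within an expected range from 2 nM to 500 nM.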

Compound 4, half-maximal effective concentration: 5.01 nM
Compound 4: middle estimate off by 4.0-fold (0.60 log units), on the high side; the measured number falls inside the stated range.
By their numbers in this assay, from the lowest: compound 3; then compound 2; then compound 4.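

Until now, the only ring with two nitrogens at this place was the pyrimidin-4-yl of compound 1, but in this assay compound 4, with 1H-pyrazol-3-yl on the same aromatic carbon, gives 5.01 nM, so a ring with two nitrogens here can still go with a low number. It does not match the other five-membered rings, however, with a 20-fold higher number from compound 3 to compound 4 (1.30 log units; beyond the scatter) and a 4.0-fold higher number from compound 2 to compound 4 (0.60 log units; beyond the scatter); unlike thiophen-3-yl, 1H-pyrazol-3-yl carries a hydrogen-bond donor, but this single comparison cannot separate that donor from the second ring nitrogen. All steps from compound 1, including the one to compound 4, cannot be read, and how far pyrimidin-4-yl lies from the other rings stays unknown because compound 1 gives a limit and not a number: the limit of < 100000 nM in this assay, at which 1 of the 4 values shown sits.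

A methyl group on the ring nitrogen of 1H-pyrazol-3-yl, or an imidazole ring with its two nitrogens arranged differently, could help to tell the donor and the second nitrogen apart. On these data alone, it also remains open how this place would respond to a group without a ring, such as an amine or a carboxylic acid.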